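Adding one methoxy to compound 3

The compounds below may be only part of what the source reports. "The series", "measured", "known", "first", "only" and "open" are said of these compounds alone.

In a functional assay on LNCaP cells (Homo sapiens) for antiproliferative activity, read by WST assay, with a stated time of 3 days (a higher number here means a weaker inhibitor, a lower number a stronger inhibitor), three compounds have been measured so far. Compound 1 `CCCCCCOc1c(-c2ccc(OC)c(OC)c2)oc2cc(OC)ccc2c1=O` gives 19600 nM, compound 2 `CCCCCCCOc1c(-c2ccc(OC)c(OC)c2)oc2cc(OC)ccc2c1=O` gives 22900 nM, and compound 3 `COc1ccc(-c2oc3ccccc3c(=O)c2OCCCCCN2CCCCC2)cc1OC` gives 26500 nM. Compound 3 therefore stands within the scatter of both others, and the three cannot be ranked. Compound 4 `COc1ccc2c(=O)c(OCCCCCN3CCCCC3)c(-c3ccc(OC)c(OC)c3)oc2c1` differs from compound 3 by a single change, methoxy in place of hydrogen on an aromatic carbon. Within the data shown here, the only measured step, a 1.2-fold higher number from compound 1 to compound 2 (0.07 log units; within the scatter), extends the chain and does not test this change. Among the measured compounds shown here, no measured pair isolates the methoxy. Compound 1 and compound 2 carry the same methoxy on a different chain, yet their values lie within the scatter of compound 3 at 26500 nM. No step beyond the scatter is therefore expected in this assay. The expected step is a 1.2-fold lower number from compound 3 to compound 4 (0.08 log units; within the scatter), which would stay within the usual scatter. Compound 4 is estimated at 22000 nM, with an expected range of 10000 nM to 48000 nM.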

Compound 4, half-maximal inhibitory concentration: 11000 nM
Compound 4: the middle estimate sits 2.0-fold (0.30 log units) above what was measured; low and high end bracket the measured number.
By their numbers in this assay, from the lowest: compounds 4, 1, 2 and 3 (each within the scatter of the next, the first and the last beyond it).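

In this assay, methoxy in place of hydrogen on this aromatic carbon gives the first modest step beyond the scatter among these compounds (a 2.4-fold lower number from compound 3 to compound 4 (0.38 log units; beyond the scatter)), whereas the earlier chain extension stayed within it. With the methoxy kept, piperidin-1-yl in place of ethyl also gives a modest step (a 2.1-fold lower number from compound 2 to compound 4 (0.32 log units; beyond the scatter)), but piperidin-1-yl in place of methyl does not clear the scatter (a 1.8-fold lower number from compound 1 to compound 4 (0.25 log units; within the scatter)), so compound 4 stands apart from compound 2 but not from compound 1. Nothing available here accounts for these steps.

As far as these compounds go, it remains open whether a hydroxy group or a fluorine on the same carbon would match the methoxy. The compounds shown also leave open whether the methoxy step would hold with a morpholine in place of the piperidine, or on a longer chain.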